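Swapping a hydroxyphenyl for a methoxyphenyl on compound 1

The source may report more compounds than this note shows. Statements on the series, on what has been measured and on what is new or still open speak of the compounds shown alone.

Measured compounds:
compound 1 `Cc1cc(-c2ccc(O)cc2)c2ncc(CSCCc3ccccc3)n2c1`, 13.7 ug/mL
compound 2 `COc1cccc(-c2cc(C)c3ncc(CSCCc4ccccc4)n3c2)c1`, 36 ug/mL
compound 3 `Cc1cc(-c2cccs2)cn2c(CSCCc3ccccc3)cnc12`, 32 ug/mL

In an ADME assay on HEL cells (Homo sapiens) for cytotoxicity, with a stated time of 3 days (a higher number here means that more compound is tolerated, a lower number that less compound is tolerated), compound 1 gives the lowest of the three numbers, with compound 3 and compound 2 both beyond the scatter above it. Compound 4 `COc1cccc(-c2cc(C)cn3c(CSCCc4ccccc4)cnc23)c1` is compound 1 with one change: 3-methoxyphenyl in place of 4-hydroxyphenyl on an aromatic carbon. For the measured compounds named here, no measured step changes this same group on this same carbon. Going by the values given here, the only measured step, a 1.1-fold lower number from compound 2 to compound 3 (0.05 log units; within the scatter), shows that exchanging the aromatic group left this assay unchanged in a related pair, though compound 2 and compound 3 carry their aromatic group on a different carbon than compound 1 does. Since compound 2 carries the entering group and gives 36 ug/mL, compound 4 is expected to rise modestly, by about a 1.8-fold higher number from compound 1 to compound 4 (0.26 log units; within the scatter), to an estimated 25 ug/mL, within 10 ug/mL to 55 ug/mL.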

Compound 4, half-maximal cytotoxic concentration: > 50 ug/mL
Compound 4: a limit, no number; the forecaster's own chance of this, stated with the estimate: 5%; at least 2.0-fold (0.30 log units) between middle value and limit.
By their numbers in this assay, from the lowest: compound 1; then compounds 3 and 2 (each within the scatter of the next). At a limit, above all of these: compound 4.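

In this assay, placing 3-methoxyphenyl instead of 4-hydroxyphenyl on this carbon gives an at least 3.6-fold higher number from compound 1 to compound 4 (0.56 log units; beyond the scatter). For the compounds shown here, an exchange of aromatic group here can therefore shift the result, unlike the one earlier exchange, on a different carbon, which stayed within the scatter. Compound 4 gives > 50 ug/mL, which is a limit of the assay and not a number.

From the compounds shown here alone, the hydroxyl-to-methoxy exchange and the move of the oxygen group around the ring happen together, so their separate contributions remain open. So does the outcome with 3-hydroxyphenyl, 4-methoxyphenyl or an aminophenyl group on this carbon.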